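Swapping the aryl group on the shared core

The source may hold more compounds than are shown below. What is called first, only, known or untested is meant among the compounds shown, and "the series" means these compounds.

Measured so far:
compound 1 `CSc1ccc(C2=NN(C(=S)Nc3ccccc3)C(c3ccc4c(c3)OCCO4)C2)cc1` with 193000 nM in a functional assay on HCT-116 cells (Homo sapiens) for antiproliferative activity, read by MTT assay, with a stated time of 48 h; a higher number here means a weaker inhibitor of growth, a lower number a stronger inhibitor of growth
compound 2 `S=C(Nc1ccccc1)N1N=C(c2cccc(Cl)c2)CC1c1ccc2c(c1)OCCO2` with 138000 nM in this assay

Among the compounds with values here, compound 2 is one of only two measured compounds, and its number and that of compound 1 lie within the scatter of each other, as the step of a 1.4-fold lower number from compound 1 to compound 2 (0.15 log units; within the scatter) shows. Compound 3 `S=C(Nc1ccccc1)N1N=C(c2cccs2)CC1c1ccc2c(c1)OCCO2` has not yet been measured. It differs from compound 2 by thiophen-2-yl in place of 3-chlorophenyl on a carbon with a double bond to nitrogen. Within the data shown here, the only measured step, a 1.4-fold lower number from compound 1 to compound 2 (0.15 log units; within the scatter), also exchanges the aromatic group on a carbon with a double bond to nitrogen, and it stayed within the scatter. From this single comparison, an exchange of one aromatic group for another on that carbon is expected to give no step beyond the scatter, a 1.1-fold higher number from compound 2 to compound 3 (0.04 log units; within the scatter). For compound 3 the expected value in this assay is 150000 nM, with a range from 60000 nM to 400000 nM.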

Compound 3, concentration for 50% growth inhibition: 8190 nM
For compound 3 the middle estimate is 18-fold (1.26 log units) above the measured one; the measured number lies below the stated range.
By their numbers in this assay, from the lowest: compound 3; then compounds 2 and 1 (each within the scatter of the next).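

The carbon with a double bond to nitrogen is not indifferent to which aromatic group it carries. Two substituted six-membered rings had given values within the scatter of each other, but thiophen-2-yl, a five-membered aromatic ring with one hetero atom, moves the result well beyond it in this assay, both against 3-chlorophenyl (a 17-fold lower number from compound 2 to compound 3 (1.23 log units; beyond the scatter)) and against 4-(methylsulfanyl)phenyl (a 24-fold lower number from compound 1 to compound 3 (1.37 log units; beyond the scatter)). Compound 3 is thus the strongest inhibitor of growth of the three, though no measurement here explains why this change matters so much.

The compounds shown leave open whether the smaller ring or its sulfur atom goes with the lower number. A furan-2-yl or thiophen-3-yl group at this position could separate those two features.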